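The compounds below may be only part of what the source reports. "The series", "measured", "known", "first", "only" and "open" are said of these compounds alone.

Working notes on the series

Compound 1 `Clc1cc2[nH]nc(-c3cnn(-c4ccccc4)c3)c2cc1N[C@@H]1CCNC1` is the reference point; in an assay on isolated protein for inhibition of tyrosine-protein kinase receptor UFO (Homo sapiens), with a stated time of 1.5 h (on this read-out higher numbers stand for weaker inhibition and lower numbers for stronger inhibition), compound 1 gives 1700 nM. Compound 2 `Fc1ccc(-n2cc(-c3n[nH]c4cc(Cl)c(N[C@@H]5CCNC5)cc34)cn2)cc1` carries a fluoro in place of hydrogen on an aromatic carbon, and in this assay compound 2 gives 2300 nM. Going by the values given here, that step, a 1.4-fold higher number from compound 1 to compound 2 (0.13 log units; within the scatter), is the only measured step in the set. Compound 2 thus stands at the higher of the two numbers shown, but compound 1 lies within the scatter of it, so no order between the two can be stated.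

Compound 3 `N#Cc1ccccc1-n1cc(-c2n[nH]c3cc(Cl)c(N[C@@H]4CCNC4)cc23)cn1` is not yet measured in this assay. It differs from compound 2 by 2-cyanophenyl in place of 4-fluorophenyl on an aromatic nitrogen. Among the compounds with values here, no measured step alters the group on the aromatic nitrogen; the only measured step, a 1.4-fold higher number from compound 1 to compound 2 (0.13 log units; within the scatter), exchanges one substituent on that phenyl and stays within the scatter, so it bears on this change only loosely. No step beyond the scatter is therefore expected in this assay, though the range is kept wide for want of a closer comparison. For compound 3 the expected step is a 1.1-fold higher number from compound 2 to compound 3 (0.04 log units; within the scatter). Compound 3 is estimated at 2500 nM, with a range from 800 nM to 8000 nM.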

Compound 3, half-maximal inhibitory concentration: 3200 nM
Compound 3: the middle estimate sits 1.3-fold (0.11 log units) below what was measured; the range from low to high includes it.
By their numbers in this assay, from the lowest: compounds 1, 2 and 3 (each within the scatter of the next).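

In this assay the exchange of 4-fluorophenyl for 2-cyanophenyl on the aromatic nitrogen gives a 1.4-fold higher number from compound 2 to compound 3 (0.14 log units; within the scatter) and a nitrile on the phenyl of compound 1 gives a 1.9-fold higher number from compound 1 to compound 3 (0.27 log units; within the scatter) as the second reading of this change. The position therefore takes a nitrile-bearing phenyl, with its added hydrogen-bond acceptor, without any step beyond the scatter, so compounds 1, 2 and 3 cannot be separated on this read-out. No supporting data bear on this result.

Going by these compounds, all three compounds keep a phenyl ring on this nitrogen, so it remains open whether a group without that ring, such as a short alkyl chain, an amine or a carboxylic acid, would give a step beyond the scatter. On these data alone, the effect of a nitrile elsewhere on the phenyl also remains open.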